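Cyano in Place of Methyl: What to Expect for Compound 4

The compounds below may be only part of what the source reports. "The series", "measured", "known", "first", "only" and "open" are said of these compounds alone.

Compound 1 `O=C1c2ccccc2C(=O)N1c1nc(-c2ccccc2)cs1`: 43900 nM
Compound 2 `O=C1c2ccccc2C(=O)N1c1nc(-c2ccc(F)cc2)cs1`: 37200 nM
Compound 3 `Cc1ccc(-c2csc(N3C(=O)c4ccccc4C3=O)n2)cc1`: 38400 nM

In a functional assay on PC-3 cells (Homo sapiens) for antiproliferative activity, read by MTT assay, with a stated time of 48 h (a higher number here means a weaker inhibitor, a lower number a stronger inhibitor), compound 3 gives 38400 nM, which sits among the other two numbers: the steps of a 1.1-fold lower number from compound 1 to compound 3 (0.06 log units; within the scatter) and a 1.0-fold higher number from compound 2 to compound 3 (0.01 log units; within the scatter) are both within the scatter, so nothing separates the three measured compounds. The unmeasured compound 4 `N#Cc1ccc(-c2csc(N3C(=O)c4ccccc4C3=O)n2)cc1` differs from compound 3 by cyano in place of methyl on an aromatic carbon. Within the data shown here, the steps that bear on this change are those that alter the same group: fluoro or methyl in place of hydrogen, a 1.2-fold lower number from compound 1 to compound 2 (0.07 log units; within the scatter) and a 1.1-fold lower number from compound 1 to compound 3 (0.06 log units; within the scatter), and methyl in place of fluoro, a 1.0-fold higher number from compound 2 to compound 3 (0.01 log units; within the scatter). None of them moved this assay beyond the scatter. A cyano group has not been tested at this place, so the expectation rests on the indifference seen so far. Compound 4 is therefore expected to give about 36000 nM, within a range of 15000 nM to 85000 nM, which means an expected step of a 1.1-fold lower number from compound 3 to compound 4 (0.03 log units; within the scatter), not beyond the scatter.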

Compound 4, half-maximal inhibitory concentration: 40300 nM
Compound 4: the middle estimate sits 1.1-fold (0.05 log units) below what was measured; low and high end bracket the measured number.
By their numbers in this assay, from the lowest: compounds 2, 3, 4 and 1 (each within the scatter of the next).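

In this assay, cyano brings to this place a triple bond and a hydrogen-bond acceptor, which none of the earlier groups had, yet the steps remain small: a 1.0-fold higher number from compound 3 to compound 4 (0.02 log units; within the scatter) against methyl, a 1.1-fold higher number from compound 2 to compound 4 (0.03 log units; within the scatter) against fluoro and a 1.1-fold lower number from compound 1 to compound 4 (0.04 log units; within the scatter) against hydrogen. The indifference of this place, on an aromatic carbon para to a large group, therefore no longer rests on hydrogen, fluoro and methyl alone, but extends to a group of a different build. No measurement at hand gives a reason for this indifference.

The compounds shown leave open whether an amine, a carboxylic acid or a longer chain at this place would move the reading beyond the scatter. They also leave open whether a change to the shared core would do so.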